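The source may hold more compounds than are shown below. What is called first, only, known or untested is meant among the compounds shown, and "the series" means these compounds.

Measured so far:
compound 1 `Nc1nc2c(s1)CC(CNC(=O)c1cc(Br)c[nH]1)CC2`, 20000 nM in an assay with sodium channel protein type 3 subunit alpha (Homo sapiens) as the target, read by patch clamp; a lower number here means a stronger inhibitor, a higher number a weaker inhibitor
compound 2 `Nc1nc2c(s1)C[C@@H](NC(=O)c1cc(Br)c[nH]1)CC2`, 26000 nM
compound 3 `Nc1nc2c(s1)C[C@@H](NC(=O)c1cc(Br)c(Br)[nH]1)CC2`, 26000 nM

Compound 2 stands level with compound 3 at the digits shown; the two share the highest numbers of the three, and compound 1 lies within the scatter of both. Among the compounds with values here, the single measured step, no change at the digits printed from compound 2 to compound 3 (within the scatter), covers a bromo in place of hydrogen on an aromatic carbon and shows nothing beyond the scatter.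

Compound 4 `Cn1cccc1C(=O)N[C@H]1CCc2nc(N)sc2C1` carries 1-methyl-1H-pyrrol-2-yl in place of 4-bromo-1H-pyrrol-2-yl on a carbonyl carbon. The bromine leaving is matched by the step from compound 2 to compound 3, which did not move the number; the methyl on the pyrrole nitrogen is not covered by any measured pair. No step beyond the scatter is therefore expected in this assay, with the estimate for compound 4 set at 30000 nM, range 12000 nM to 80000 nM, a step of a 1.2-fold higher number from compound 2 to compound 4 (0.06 log units; within the scatter) from compound 2.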

Compound 4, half-maximal inhibitory concentration: 24000 nM
Beside the measured number, compound 4's estimate is 1.3-fold (0.10 log units) above it; the range from low to high includes it.
By their numbers in this assay, from the lowest: compounds 1, 4, 2 and 3 (each within the scatter of the next).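

In this assay the group on the carbonyl carbon can lose its bromine and gain a methyl on the pyrrole nitrogen with no step beyond the scatter (a 1.1-fold lower number from compound 2 to compound 4 (0.03 log units; within the scatter)). The earlier step only added a bromo; this one also removes the hydrogen-bond donor counted on the leaving group, and the number still stays within the scatter. Nothing measured on hand explains this flat result.

The two parts of the change remain unseparated, since unsubstituted 1H-pyrrol-2-yl is not among the compounds shown. As far as these compounds go, whether an amine or carboxylic acid on the pyrrole would shift the number also stays open.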